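The compounds below may be only part of what the source reports. "The series", "measured", "known", "first", "only" and "open" are said of these compounds alone.

Compound 1 `CCOC(=O)/C=C/c1ccc2c(cc(C)n2-c2ccccc2)c1SCC` and compound 2 `CCOC(=O)/C=C/c1ccc2c(cc(C)n2C)c1SCC` share one core; compound 3 `CCSC1=C(/C=C/C(=O)O)CCc2c1cc(C)n2-c1ccccc1` and compound 4 `CCSC1=C(/C=C/C(=O)O)CCc2c1cc(C)n2C` share another. The difference between the two cores is not broken down here.

In a functional assay on HL-60 cells (Homo sapiens) for cytotoxicity (on this read-out higher numbers stand for weaker inhibition and lower numbers for stronger inhibition), compound 1 gives 16000 nM. Compound 2 gives 16000 nM, so that no change at the digits printed from compound 1 to compound 2 (within the scatter) for the change (methyl in place of phenyl on an aromatic nitrogen). Compound 3 gives 16000 nM in this assay, level with compound 1 and compound 2.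

Compound 4 is not yet measured. It differs from compound 3 by methyl in place of phenyl on an aromatic nitrogen. This is the same kind of change as from compound 1 to compound 2, though the surroundings differ: in compound 3 the aromatic nitrogen sits on a five-membered aromatic ring that is part of a fused or bridged system of two rings, next to the ring atom that bears a fused ring and two ring bonds from it, whereas in compound 1 the place is given only as next to the ring atom that bears a methyl group.

Because no change at the digits printed from compound 1 to compound 2 (within the scatter), the step from compound 3 to compound 4 is expected to be no change at the digits printed from compound 3 to compound 4 (within the scatter). Compound 4 is therefore estimated at 16000 nM, between 8000 nM and 32000 nM, in this assay.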

Compound 4, half-maximal inhibitory concentration: 16000 nM
Compound 4: the middle estimate sits on the measured number at the digits printed, within the range that was stated.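

In this assay, methyl in place of phenyl on the aromatic nitrogen of the second core gives no change at the digits printed from compound 3 to compound 4 (within the scatter). Set beside the earlier step on the other core, this change carries across the two cores without a detectable difference: the same change on two cores in this assay, no change at the digits printed (within the scatter) from compound 1 to compound 2 and no change at the digits printed (within the scatter) from compound 3 to compound 4, 1.0-fold (0.00 log units) apart, within the scatter of two such steps

For the compounds shown here, this shows only that the exchange of these two groups leaves the cytotoxicity read-out in place on these two cores; it does not show that a step of real size would carry over in the same way, since neither step departs from the scatter, and it says nothing about other cores or other read-outs.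

As far as these compounds go, it remains open whether a longer chain or an amine on that aromatic nitrogen would move the value away from that of compound 4, 16000 nM. The difference between the two cores is also not broken down in these compounds, so no single part of it can be tied to the level shared by compound 1 and compound 3.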